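Diaryl urea series: chloro for trifluoromethyl on the terminal ring

The source may hold more compounds than are shown below. What is called first, only, known or untested is meant among the compounds shown, and "the series" means these compounds.

Compound 1 `COc1cc2cc(Oc3ccc(NC(=O)Nc4ccccc4)cc3)c(C)nc2cc1OC`: 38.8%
Compound 2 `COc1cc2cc(Oc3ccc(NC(=O)Nc4ccc(Cl)c(C(F)(F)F)c4)cc3)c(C)nc2cc1OC`: -26.4%

In a functional assay on RPMI-8226 cells (Homo sapiens) for inhibition, read by sulforhodamine B assay, with a stated time of 48 h, tested at 10 uM (on this read-out lower numbers stand for a stronger effect and higher numbers for a weaker effect at the one concentration tested), compound 1 gives 38.8% and compound 2 gives -26.4%. For the measured compounds named here, compound 2 stands lowest of the two numbers; the only step to it, a number 65.2 percentage points lower from compound 1 to compound 2 (beyond the scatter), is large and beyond the scatter, and it puts a chloro group and a trifluoromethyl group onto the terminal phenyl of the urea.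

Compound 3 `COc1cc2cc(Oc3ccc(NC(=O)Nc4ccc(Cl)c(Cl)c4)cc3)c(C)nc2cc1OC` keeps that chloro and changes the other substituent: chloro in place of trifluoromethyl on an aromatic carbon, that is, 4-chloro-3-(trifluoromethyl)phenyl becomes 3,4-dichlorophenyl. Going by the values given here, no measured step tests this swap directly. Among the compounds with values here, the one step known, from the bare phenyl to the doubly substituted ring, bears on it only loosely, since compound 3 keeps a doubly substituted ring of the same kind. A small step, if any, is therefore expected in this assay, most likely toward slightly higher numbers: a number 11.4 percentage points higher from compound 2 to compound 3 (beyond the scatter). Compound 3 is estimated at -15%, with a range from -45% to 20%.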

Compound 3, a percentage reported as activity, at one concentration (the size of the read-out at that concentration, not a potency): 4.2%
For compound 3 the middle estimate is 19.2 percentage points below the measured one; the range from low to high includes it.
By their numbers in this assay, from the lowest: compound 2; then compound 3; then compound 1.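

In this assay the place ortho to a chloro group on the terminal ring proves sensitive to the swap: chloro in place of trifluoromethyl gives a number 30.6 percentage points higher from compound 2 to compound 3 (beyond the scatter), so the two groups are not interchangeable there. The 3,4-dichlorophenyl ring still keeps part of the gain over the bare phenyl, with a number 34.6 percentage points lower from compound 1 to compound 3 (beyond the scatter), so in these three compounds the stronger effect of a substituted ring does not require trifluoromethyl. No measurement at hand explains why the two groups differ at this place.

The compounds shown do not separate the contribution of each substituent, as no ring here carries the chloro or the trifluoromethyl alone. As far as these compounds go, whether a nitrile or a carboxylic acid at this place would fall nearer the trifluoromethyl or the chloro value also remains open.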